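Removing the methoxy group from a hydroxylated stilbene-like scaffold

This account rests on a few compounds, and the source may have more. Where it says the series, first, only, none or still open, it means among the compounds named here.

Measured compounds:
- compound 1, `COc1cc(/C=C/c2cc(C)no2)ccc1O`: 34600 nM
- compound 2, `CC(=O)/C=C(O)/C=C/c1ccc(O)c(O)c1`: 32200 nM

Of the compounds shown here, two have so far been tested in a functional assay on MDA-MB-231 cells (Homo sapiens) for cytotoxicity, read by MTT assay, with a stated time of 72 h; on this read-out higher numbers stand for weaker inhibition and lower numbers for stronger inhibition. Compound 1 gives 34600 nM, the highest of the two numbers, while compound 2 gives 32200 nM; the gap between them lies within the scatter, so the two cannot be ordered. For the measured compounds named here, no step between measured compounds differing in a single place is available, so the effect of small changes on this scaffold remains unknown from these data alone.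

Compound 3, `Cc1cc(/C=C/c2ccc(O)cc2)on1`, is not yet measured. It differs from compound 1 in one place: hydrogen in place of methoxy on an aromatic carbon. The change is a small trimming of the ring that carries the hydroxy group, and the two measured compounds offer no guidance on what such a change does here. The step is expected to be small, if anything towards a slightly weaker inhibition, so that a 1.3-fold higher number from compound 1 to compound 3 (0.11 log units; within the scatter) stays within or near the scatter. Compound 3 is therefore estimated to give 45000 nM in this assay, with a plausible range from 15000 nM to 140000 nM.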

Compound 3, half-maximal inhibitory concentration: 55500 nM
Compound 3: the middle estimate sits 1.2-fold (0.09 log units) below what was measured; the measured number falls inside the stated range.
By their numbers in this assay, from the lowest: compounds 2, 1 and 3 (each within the scatter of the next).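

In this assay, for the compounds shown here, the series now has its first step that changes a single place: with hydrogen in place of methoxy on an aromatic carbon, ortho to a hydroxy group, the result is a 1.6-fold higher number from compound 1 to compound 3 (0.21 log units; within the scatter), and this is the only such step available so far. The methoxy group at this position is therefore not shown to matter on this read-out, since compound 1 and compound 3 cannot be told apart, something the two earlier compounds could not address. No measurement is at hand that would account for the step in any way.

From the compounds shown here alone, it remains open whether any other group at this same place, such as an amine, a chlorine atom or a longer alkoxy chain, would move the number beyond the scatter from compound 1 or compound 3. Equally open, going by these compounds, is what the hydroxy group itself contributes, and whether replacing it with an amine or a carboxylic acid on the shared core would matter more than the step seen at the neighbouring methoxy position.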